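Swapping Ethoxy for Fluoro in a Small Series

A few compounds are considered here, and "the series" means these few. Any claim that something is new, unique, unknown or untested is made for them only; others in the source may bear on it.

In a functional assay on A549 cells (Homo sapiens) for antiproliferative activity, read by MTT assay, with a stated time of 72 h (on this read-out higher numbers stand for weaker inhibition and lower numbers for stronger inhibition), compound 3 `CCOc1ccc(NC2=C(C(=O)c3ccccc3)C(c3ccc(Br)cc3)N(CCCn3ccnc3)C2=O)cc1` gives 20200 nM, the lowest of the three numbers shown, though all three lie within the scatter of one another. Compound 1 `O=C(C1=C(Nc2ccccc2)C(=O)N(CCCn2ccnc2)C1c1ccc(Br)cc1)c1ccccc1` gives 24100 nM and compound 2 `Cc1ccc(NC2=C(C(=O)c3ccccc3)C(c3ccc(Br)cc3)N(CCCn3ccnc3)C2=O)cc1` gives 29400 nM in this assay. The measured steps of a 1.2-fold higher number from compound 1 to compound 2 (0.09 log units; within the scatter), a 1.2-fold lower number from compound 1 to compound 3 (0.08 log units; within the scatter) and a 1.5-fold lower number from compound 2 to compound 3 (0.16 log units; within the scatter) all stay within the scatter. Compound 4 `O=C(C1=C(Nc2ccc(F)cc2)C(=O)N(CCCn2ccnc2)C1c1ccc(Br)cc1)c1ccccc1` carries fluoro in place of ethoxy on an aromatic carbon. Every measured step alters the same aromatic carbon, exchanging hydrogen, methyl and ethoxy, and none shifted the number beyond the scatter, so the step to compound 4 is expected to be similarly small, a 1.2-fold higher number from compound 3 to compound 4 (0.07 log units; within the scatter). Compound 4 is therefore estimated at 24000 nM, with a range from 12000 nM to 50000 nM.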

Compound 4, half-maximal inhibitory concentration: 27400 nM
Compound 4: the middle estimate sits 1.1-fold (0.06 log units) below what was measured; the measured number falls inside the stated range.
By their numbers in this assay, from the lowest: compounds 3, 1, 4 and 2 (each within the scatter of the next).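

In this assay, fluoro on this aromatic carbon, para to a large group, adds a halogen to the hydrogen, methyl and ethoxy seen before, and all of its steps stay within the scatter (a 1.4-fold higher number from compound 3 to compound 4 (0.13 log units; within the scatter)) and (a 1.1-fold lower number from compound 2 to compound 4 (0.03 log units; within the scatter)) and (a 1.1-fold higher number from compound 1 to compound 4 (0.06 log units; within the scatter)). Across these four compounds, then, the position tolerates the exchange of ethoxy for fluoro without a readable shift in the number. No evidence at hand speaks to why these groups read alike. On these data alone, whether an amine or a carboxylic acid on this carbon would also stay within the scatter remains open. So does whether a change elsewhere on the shared core would move the number.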